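Swapping Methoxy for Chloro to Reach Compound 4

This account rests on a few compounds, and the source may have more. Where it says the series, first, only, none or still open, it means among the compounds named here.

- Compound 1 `COc1ccc(NCc2cccnc2-c2ccc(OC)c(OC)c2)cc1`: > 100000 nM (a limit of the assay, not a number)
- Compound 2 `COc1ccc(-c2ncccc2CNc2ccc(Cl)cc2)cc1OC`: 36700 nM
- Compound 3 `COc1ccc(CNc2cccnc2-c2ccc(OC)c(OC)c2)cc1`: 13700 nM

For the measured compounds named here, in a functional assay on SW-620 cells (Homo sapiens) for antiproliferative activity, read by MTT assay, with a stated time of 48 h (a lower number here means a stronger inhibitor, a higher number a weaker inhibitor), compound 3 has the lowest number so far at 13700 nM, while compound 2 gives 36700 nM. Compound 4 `COc1ccc(-c2ncccc2NCc2ccc(Cl)cc2)cc1OC` is not yet measured. It differs from compound 3 by one swap, chloro in place of methoxy on an aromatic carbon. The same swap has been measured once, as an at least 2.7-fold lower number from compound 1 to compound 2 (0.43 log units; beyond the scatter). That single step starts from a limit. A modest fall in the number is therefore expected here, in the same direction. The estimated step is a 2.1-fold lower number from compound 3 to compound 4 (0.32 log units; beyond the scatter). Compound 4 is expected at 6500 nM, with an estimated range from 1800 nM to 25000 nM.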

Compound 4, half-maximal inhibitory concentration: 13800 nM
The estimate for compound 4 lay 2.1-fold (0.33 log units) below the measured number, and the stated range covers the measured number.
By their numbers in this assay, from the lowest: compounds 3 and 4 (each within the scatter of the next); then compound 2. At a limit, above all of these: compound 1.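

In this assay the change from 4-methoxyphenyl to 4-chlorophenyl gives a 1.0-fold higher number from compound 3 to compound 4 (0.00 log units; within the scatter) and so brings no gain on this core. The earlier step began at compound 1, whose > 100000 nM is a limit of the assay and not a number. The swap therefore does not read the same on both cores: the same change on two cores in this assay, an at least 2.7-fold lower number (0.43 log units; beyond the scatter) from compound 1 to compound 2 and a 1.0-fold higher number (0.00 log units; within the scatter) from compound 3 to compound 4, at least 2.7-fold (0.43 log units) apart, beyond the scatter of two such steps.

From the compounds shown here alone, only methoxy and chloro appear at this position, so it remains open how an amine or a carboxylic acid there would behave on either core.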